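This account rests on a few compounds, and the source may have more. Where it says the series, first, only, none or still open, it means among the compounds named here.

Measured compounds:
Compound 1, `NS(=O)(=O)c1cc(-c2nnc(CN3CCN(c4ccccc4)CC3)o2)c(Cl)cc1SCc1ccccc1`: 295000 nM
Compound 2, `NCc1nnc(-c2cc(S(N)(=O)=O)c(SCc3ccccc3)cc2Cl)o1`: 135000 nM

In a functional assay on MCF7 cells (Homo sapiens) for cytotoxicity, read by MTT assay, with a stated time of 72 h (a higher number here means a weaker inhibitor, a lower number a stronger inhibitor), compound 2 gives the lower of the two numbers shown, and the one known step separates it from its neighbour: a 2.2-fold lower number from compound 1 to compound 2 (0.34 log units; beyond the scatter). Compound 3, `NS(=O)(=O)c1cc(-c2nnc(/C=C/c3ccc(Br)cc3)o2)c(Cl)cc1SCc1ccccc1`, carries 2-(4-bromophenyl)ethenyl in place of aminomethyl on an aromatic carbon. Within the data shown here, that known step altered only the end of the chain and was modest, and no step touches a swap of this kind on the ring carbon, so it bears on the new change only loosely. Both numbers are high, and compound 3 is expected to stay in that region, with a 1.5-fold higher number from compound 2 to compound 3 (0.17 log units; within the scatter). Compound 3 is estimated at 200000 nM, within 50000 nM to 600000 nM.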

Compound 3, half-maximal inhibitory concentration: 13000 nM
Estimate against measurement, compound 3: 15-fold (1.19 log units) above, and the stated range ends above it.
By their numbers in this assay, from the lowest: compound 3; then compound 2; then compound 1.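

In this assay this aromatic carbon of the five-membered aromatic ring proves far more responsive than the earlier change suggested: 2-(4-bromophenyl)ethenyl in place of aminomethyl gives a 10-fold lower number from compound 2 to compound 3 (1.02 log units; beyond the scatter) and so outweighs a 2.2-fold lower number from compound 1 to compound 2 (0.34 log units; beyond the scatter) in size. The entering group adds a carbon-only aromatic ring, a double bond and a bromine at once, so this single step cannot assign the gain to any one of them. No measurement shown here explains the gain. The compounds shown leave open how an unsubstituted 2-phenylethenyl group or a saturated 2-(4-bromophenyl)ethyl chain would compare.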